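The compounds below may be only part of what the source reports. "The series", "measured", "known", "first", "only" and "open" are said of these compounds alone.

Three compounds have been measured in a functional assay on MGC-803 cells (Homo sapiens) for inhibition, read by sulforhodamine B assay, with a stated time of 72 h, tested at 10 uM; a higher number here means more inhibition at the concentration tested (going by the name of the read-out), a lower number less inhibition:
compound 1 `Cc1cc(Nc2ccc(C(=O)/C=C/c3cccc(Br)n3)cc2)n2nc(SCc3ccc([N+](=O)[O-])cc3)nc2n1` gives 91.6%;
compound 2 `Cc1cc(Nc2ccc(C(=O)/C=C/c3ccccc3)cc2)n2nc(SCc3nc4ccccc4[nH]3)nc2n1` gives 94.5%;
compound 3 `Cc1cc(Nc2ccc(N3CCN(C)CC3)cc2)n2nc(SCc3nc4ccccc4[nH]3)nc2n1` gives 78.1%.

Compound 1 stands second highest of these three numbers. Compound 2 lies within the scatter of it, while compound 3 lies beyond the scatter below it. Among the measured compounds shown here, the only step recorded among the measured compounds, a number 16.4 percentage points lower from compound 2 to compound 3 (beyond the scatter), concerns the substituent on the aromatic carbon of the outer ring, so it speaks to the enone side of the molecule and not to the thioether arm on the fused core.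

Compound 4 `Cc1cc(Nc2ccc(C(=O)/C=C/c3cccc(Br)n3)cc2)n2ncnc2n1` differs from compound 1 in hydrogen in place of (4-nitrobenzyl)sulfanyl on an aromatic carbon. For the measured compounds named here, no measured step touches this place: compounds 1, 2 and 3 all carry a sulfanyl-linked arm there, and all three give high numbers. Compound 4 keeps the bromopyridinyl enone of compound 1, which in compounds 1 and 2 accompanies the highest numbers, but it loses the whole arm. Without a comparison at that position, the size of the step is uncertain; a modest fall seems the more likely outcome, and the estimated step is a number 21.6 percentage points lower from compound 1 to compound 4 (beyond the scatter). Compound 4 is therefore expected to give about 70%, within a range from 40% to 95%.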

Compound 4, a percentage reported as inhibition, at one concentration (the size of the read-out at that concentration, not a potency): 58.4%
The estimate for compound 4 lay 11.6 percentage points above the measured number; low and high end bracket the measured number.
By their numbers in this assay, from the lowest: compound 4; then compound 3; then compounds 1 and 2 (each within the scatter of the next).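

In this assay, the step at this position is large: a number 33.2 percentage points lower from compound 1 to compound 4 (beyond the scatter), on the aromatic carbon of the five-membered aromatic ring, between two ring nitrogen atoms. Until now, every compound carried a sulfanyl-linked arm at this carbon, so the bromopyridinyl enone could not be judged without one; compound 4 keeps that enone, and replacing (4-nitrobenzyl)sulfanyl with hydrogen shows that the enone alone does not hold the number at the level of compound 1, although compound 4 still gives 58.4%. Nothing available explains why the number falls with this change.

The change removes the sulfur link, the benzyl ring and the nitro group together, so the compounds shown cannot say how much of the step belongs to each part, a question that a small methylsulfanyl group or a 4-aminobenzyl arm at the same carbon would address. On these data alone, it also remains open whether removing the different sulfanyl-linked arm of compound 2 would give a step of similar size.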